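The source may hold more compounds than are shown below. What is called first, only, known or untested is meant among the compounds shown, and "the series" means these compounds.

Within the data shown here, compound 3 `CC(C)n1nc(N2CC(C(C)(C)O)C2)c2cnc(Nc3ccnc(-c4cnn(S(=O)(=O)C5CC5)c4)n3)cc21` stands at the top of the three numbers so far in an ADME assay on MDCK cells (Canis lupus familiaris) for permeability, in the apical to basolateral direction (a lower number here means that the compound crosses the layer more slowly, a higher number that the compound crosses the layer faster), with compound 3 at 20 10^-6 cm/s. Its nearest neighbour is compound 1 `CC(C)n1nc(N)c2cnc(Nc3ccnc(-c4cnn(S(=O)(=O)C5CC5)c4)n3)cc21`, which in this assay gives 16 10^-6 cm/s; compound 2 `CC(C)n1nc(N2CC(CO)C2)c2cnc(Nc3ccnc(-c4cnn(S(=O)(=O)C5CC5)c4)n3)cc21` gives 8.1 10^-6 cm/s. The change to compound 4 `CC(C)c1nn(C(C)C)c2cc(Nc3ccnc(-c4cnn(S(=O)(=O)C5CC5)c4)n3)ncc12` is isopropyl in place of 3-(1-hydroxy-1-methylethyl)azetidin-1-yl on an aromatic carbon. The bearing steps are a 1.3-fold higher number from compound 1 to compound 3 (0.10 log units; within the scatter), a 2.0-fold lower number from compound 1 to compound 2 (0.30 log units; within the scatter) and a 2.5-fold higher number from compound 2 to compound 3 (0.39 log units; beyond the scatter); none exchanges the whole group for isopropyl, so the direction rests on the narrow spread of the three values. A step of about a 1.2-fold higher number from compound 3 to compound 4 (0.08 log units; within the scatter) is expected, not clearly beyond the scatter. Compound 4 is estimated at 24 10^-6 cm/s, within 11 10^-6 cm/s to 50 10^-6 cm/s.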

Compound 4, apparent permeability: 3.9 10^-6 cm/s
For compound 4 the middle estimate is 6.2-fold (0.79 log units) above the measured one, and the stated range ends above it.
By their numbers in this assay, from the lowest: compound 4; then compounds 2, 1 and 3 (each within the scatter of the next, the first and the last beyond it).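

In this assay, isopropyl on this aromatic carbon gives the lowest number of the series, with a 5.1-fold lower number from compound 3 to compound 4 (0.71 log units; beyond the scatter), a 2.1-fold lower number from compound 2 to compound 4 (0.32 log units; beyond the scatter) and a 4.1-fold lower number from compound 1 to compound 4 (0.61 log units; beyond the scatter), all beyond the scatter. The number at this position therefore depends on more than the exchange between amino and the azetidines, and a group with no ring, no oxygen and no nitrogen stands apart from all three. Nothing measured here accounts for this step.

Among these compounds, the single exchange leaves the hydroxyl and the azetidine ring unseparated. An unsubstituted azetidin-1-yl or a dimethylamino group on this carbon could show whether the number stays with compound 1 and compound 3 or drops towards compound 4.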